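From a thiophene to a furan on a shared core

The source may report more compounds than this note shows. Statements on the series, on what has been measured and on what is new or still open speak of the compounds shown alone.

In a functional assay, with a stated time of 10 min (a lower number here means a stronger inhibitor, a higher number a weaker inhibitor), compound 1 `CSc1nc(-c2ccco2)c(C#N)c(=O)n1C` gives 79 ug/mL, and compound 2 `Cn1c(NN)nc(-c2cccs2)c(C#N)c1=O` gives 53 ug/mL. Compound 2 holds the lowest of the two numbers, but compound 1 stands only a little higher, within the usual scatter, so no order between the two can be drawn. They also differ in more than one place, so no single step between them is shown.

Compound 3 `Cn1c(NN)nc(-c2ccco2)c(C#N)c1=O` is the one not yet measured. It differs from compound 2 in one place: furan-2-yl in place of thiophen-2-yl on an aromatic carbon. Since compound 1 carries the same furan-2-yl group and gives 79 ug/mL close to compound 2, the data give no ground to expect a large effect from this change. Compound 3 is expected to give 60 ug/mL in this assay, with a range from 30 ug/mL to 120 ug/mL. The estimated step of a 1.1-fold higher number from compound 2 to compound 3 (0.05 log units; within the scatter) is expected to stay within the scatter.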

Compound 3, half-maximal inhibitory concentration: 58 ug/mL
Compound 3: middle estimate off by 1.0-fold (0.01 log units), on the high side; the measured number falls inside the stated range.
By their numbers in this assay, from the lowest: compounds 2, 3 and 1 (each within the scatter of the next).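

In this assay the change from thiophen-2-yl to furan-2-yl, on the aromatic carbon ortho to a cyano group, can now be read as a single step: a 1.1-fold higher number from compound 2 to compound 3 (0.04 log units; within the scatter) leaves the two compounds within the scatter of each other, so the data do not separate these two rings at this position. The second single change, aminoamino in place of methylsulfanyl, gives a 1.4-fold lower number from compound 1 to compound 3 (0.13 log units; within the scatter) and likewise does not separate the two groups. No measurement at hand bears on why the numbers stay so close.

Both groups tried at the first position are five-membered aromatic rings with 1 hetero atom, so the compounds shown leave open what a phenyl ring or a longer chain would do there. They also leave open how an ethylamino or morpholine group would read in place of aminoamino.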